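Aryl exchange from compound 2 to compound 3

The compounds below may be only part of what the source reports. "The series", "measured", "known", "first", "only" and "open" are said of these compounds alone.

In a functional assay on A549 cells (Homo sapiens) for antiproliferative activity, read by MTT assay (on this read-out higher numbers stand for weaker inhibition and lower numbers for stronger inhibition), compound 1 (`Cn1c(=O)c(=O)n(C2CCCC2)c2nc(N/N=C/c3ccc(F)c(Cl)c3)ncc21`) gives 9410 nM as a measured number. Compound 2 (`COc1ccc(/C=N/Nc2ncc3c(n2)n(C2CCCC2)c(=O)c(=O)n3C)cc1`) gives > 100000 nM as a limit of the assay and not a number, so its place is known only as the limit of > 100000 nM in this assay, at which 1 of the 2 values shown sits, in this series.

Compound 3 (`Cn1c(=O)c(=O)n(C2CCCC2)c2nc(N/N=C/c3ccc(F)cc3Br)ncc21`) carries 2-bromo-4-fluorophenyl in place of 4-methoxyphenyl on a carbon with a double bond to nitrogen.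

Within the data shown here, the only measured step that bears on this change is an at least 10-fold higher number from compound 1 to compound 2 (1.02 log units; beyond the scatter) at the same place, with 4-methoxyphenyl entering for 3-chloro-4-fluorophenyl. That step is large and beyond the scatter. Here 4-methoxyphenyl leaves again and a halogen-bearing phenyl enters, so a large step towards a lower number is expected in this assay. Going by these compounds, its size stays open, as compound 2 has only a limit. The estimated change is an at least 6.6-fold lower number from compound 2 to compound 3 (0.82 log units; beyond the scatter) on this basis. For compound 3 the expected value is 15000 nM within an estimated range of 4000 nM to 60000 nM in this assay overall.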

Compound 3, half-maximal inhibitory concentration: 6590 nM
For compound 3 the middle estimate is 2.3-fold (0.36 log units) above the measured one, and the stated range covers the measured number.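

In this assay, 2-bromo-4-fluorophenyl in place of 4-methoxyphenyl on a carbon with a double bond to nitrogen gives an at least 15-fold lower number from compound 2 to compound 3 (1.18 log units; beyond the scatter), so a second halogen-bearing phenyl also avoids the loss seen with 4-methoxyphenyl, and the earlier drop is no longer tied to the 3-chloro-4-fluorophenyl of compound 1 alone. The exchange between the two halogen-bearing phenyls gives a 1.4-fold lower number from compound 1 to compound 3 (0.15 log units; within the scatter), so compound 1 and compound 3 cannot be told apart on this read-out, despite the different halogen pattern. The size of the step from the methoxy compound stays open because compound 2 has only a limit of the assay and not a number: the limit of > 100000 nM in this assay, at which 1 of the 3 values shown sits.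

Open, going by these compounds, is whether the halogens themselves matter or whether the 4-methoxyphenyl alone is what costs activity here; a plain phenyl or a phenyl carrying a carboxylic acid or an amine at this place would speak to that. The shared core is the same in all three compounds, so nothing here tells how changes elsewhere on it would read in this assay.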